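The source may report more compounds than this note shows. Statements on the series, on what has been measured and on what is new or still open speak of the compounds shown alone.

Working notes on the series, read in a functional assay on the whole organism for inhibition, with Rattus norvegicus as the target; on this read-out higher numbers stand for an effect only at larger amounts of compound and lower numbers for an effect already at smaller amounts. Compound 1 (`CCCCc1nc(SC)c(C(=O)C[S+](C)[O-])n1Cc1ccc(-c2ccccc2S(=O)(=O)NC(=O)NCc2ccccc2)cc1`) gives 0.06 mg/kg, compound 2 (`CCCCc1nc(SC)c(C(=O)C[S+]([O-])c2ccccc2)n1Cc1ccc(-c2ccccc2S(=O)(=O)NC(=O)NCc2ccccc2)cc1`) gives 0.12 mg/kg, and compound 3 (`CCCCc1nc(SC)c(C(=O)CS(=O)(=O)c2ccccc2)n1Cc1ccc(-c2ccccc2S(=O)(=O)NC(=O)NCc2ccccc2)cc1`) gives 0.02 mg/kg, the lowest of the three numbers. The measured steps are a 2.0-fold higher number from compound 1 to compound 2 (0.30 log units; within the scatter), a 3.0-fold lower number from compound 1 to compound 3 (0.48 log units; beyond the scatter) and a 6.0-fold lower number from compound 2 to compound 3 (0.78 log units; beyond the scatter).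

Compound 4 (`CCCc1nc(SC)c(C(=O)CS(=O)(=O)c2ccccc2)n1Cc1ccc(-c2ccccc2S(=O)(=O)NC(=O)NCc2ccccc2)cc1`) shortens butyl to propyl, with the rest of compound 3 unchanged: hydrogen in place of methyl on a saturated chain carbon, three bonds along the chain from an aromatic carbon. In words, this is hydrogen in place of methyl on a saturated chain carbon, three bonds along the chain from an aromatic carbon. Going by the values given here, none of the measured steps touches this chain. All of them change the group on a saturated chain carbon bound to a carbonyl carbon, so they show only how far this assay has moved in this series, and they give no direction for the new change. No step beyond the scatter is therefore expected. The expected outcome is a 1.5-fold higher number from compound 3 to compound 4 (0.18 log units; within the scatter). The estimate for compound 4 is 0.03 mg/kg, with an expected range of 0.01 mg/kg to 0.08 mg/kg.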

Compound 4, dose for 50% inhibition: 0.04 mg/kg
For compound 4 the middle estimate is 1.3-fold (0.12 log units) below the measured one; the measured number falls inside the stated range.
By their numbers in this assay, from the lowest: compounds 3, 4, 1 and 2 (each within the scatter of the next, the first and the last beyond it).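

Butyl to propyl is the first change on this chain, and in this assay it gives a 2.0-fold higher number from compound 3 to compound 4 (0.30 log units; within the scatter), so hydrogen in place of methyl at this place brings no step beyond the scatter. Going by these compounds alone, the earlier steps all changed the group on a saturated chain carbon bound to a carbonyl carbon, so this single pair is the first reading of how the number responds to the chain itself. No measured property bears on this result, so the size of the step stays unexplained.

As far as these compounds go, whether an ethyl or a pentyl chain, or a chain ending in an amine or a carboxylic acid, would keep the number in this range remains open. Also open, from the compounds shown here alone, is whether butyl to propyl gives a similar step on the structures of compound 1 and compound 2.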